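The source may hold more compounds than are shown below. What is called first, only, known or untested is meant among the compounds shown, and "the series" means these compounds.

Measured so far:
compound 1 `COc1ccc(/C=N/NC(=S)NC(C)(C)[C@H]2CC=C(C)CC2)cc1` — 7900 nM
compound 2 `CC1=CC[C@H](C(C)(C)NC(=S)N/N=C/c2cccc([N+](=O)[O-])c2)CC1` — > 100000 nM

Among the measured compounds shown here, in a functional assay on OVCAR-3 cells (Homo sapiens) for inhibition, read by sulforhodamine B assay, with a stated time of 48 h (on this read-out lower numbers stand for stronger inhibition of growth and higher numbers for weaker inhibition of growth), compound 1 gives 7900 nM, the only plain number. Compound 2 sits at a limit of the assay, > 100000 nM, so no number is available for it; this is the limit of > 100000 nM in this assay, at which 1 of the 2 values shown sits. Compound 3 `CC1=CC[C@H](C(C)(C)NC(=S)N/N=C/c2ccco2)CC1` has not been measured. Relative to compound 1 it carries furan-2-yl in place of 4-methoxyphenyl on a carbon with a double bond to nitrogen. For the measured compounds named here, no measured step of this kind exists here, so the expected change in this assay is only loosely bounded; a small shift toward weaker inhibition is expected, a 1.5-fold higher number from compound 1 to compound 3 (0.18 log units; within the scatter). Compound 3 is expected to give about 12000 nM, within 3000 nM to 60000 nM.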

Compound 3, concentration for 50% growth inhibition: 10800 nM
The estimate for compound 3 lay 1.1-fold (0.05 log units) above the measured number; measured number inside the range.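

In this assay the place on a carbon with a double bond to nitrogen takes furan-2-yl in place of 4-methoxyphenyl with no change beyond the scatter (a 1.4-fold higher number from compound 1 to compound 3 (0.14 log units; within the scatter)). Among the compounds shown here, this is the first readable step, and it shows that a five-membered aromatic ring with fewer heavy atoms holds the level of the six-membered one here. No measured property given here accounts for this step.

Compound 2 is a limit of the assay (> 100000 nM), so steps to it cannot be read. Still open, as far as these compounds go, is how an amine or a carboxylic acid would behave at this place on the shared core.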